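A single group swap on compound 1

The source may hold more compounds than are shown below. What is called first, only, known or untested is meant among the compounds shown, and "the series" means these compounds.

In a functional assay on MCF7 cells (Homo sapiens) for inhibition, read by MTT assay, with a stated time of 72 h (on this read-out higher numbers stand for weaker inhibition and lower numbers for stronger inhibition), compound 1 (`O=C(O)CCCCCCC(=O)Nc1ccc(C2=C(c3ccc(O)cc3)C3CC(S(=O)(=O)Oc4ccccc4C(F)(F)F)C2O3)cc1`) gives 26100 nM as its half-maximal inhibitory concentration. Two relatives have also been measured: compound 2 (`O=C(CCCCCCC(=O)Nc1ccc(C2=C(c3ccc(O)cc3)C3CC(S(=O)(=O)Oc4ccccc4)C2O3)cc1)NO`) gives 30100 nM and compound 3 (`O=C(O)CCCCCCC(=O)Nc1ccc(OS(=O)(=O)C2CC3OC2C(c2ccc(O)cc2)=C3c2ccc(O)cc2)cc1`) gives 19100 nM on the same read-out. All three numbers lie within the usual scatter of repeated measurements of one another, so compound 1 cannot be told apart from either relative and no ranking can be drawn.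

The next compound to be tested is compound 4 (`O=C(O)CCCCCCC(=O)Nc1ccc(C2=C(c3ccc(O)cc3)C3CC(S(=O)(=O)Oc4ccc(F)cc4)C2O3)cc1`). It carries 4-fluorophenyl in place of 2-(trifluoromethyl)phenyl on an oxygen whose other neighbour is the sulfonyl sulfur (4-fluorophenyl in place of 2-(trifluoromethyl)phenyl on an oxygen), and the rest of the molecule stays the same.

Among the compounds with values here, no two measured compounds differ in just one place, so there is no direct measurement of what a single swap like this does. The expectation rests only on how closely the measured values agree, with compound 3 at 19100 nM and compound 2 at 30100 nM both within the scatter of compound 1. An estimated 1.1-fold lower number from compound 1 to compound 4 (0.04 log units; within the scatter) stays within the usual scatter, so no real change in either direction is expected. For compound 4 the estimated value is 24000 nM with an expected range (11000 nM to 50000 nM).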

Compound 4, half-maximal inhibitory concentration: 24800 nM
For compound 4 the middle estimate is 1.0-fold (0.01 log units) below the measured one; low and high end bracket the measured number.
By their numbers in this assay, from the lowest: compounds 3, 4, 1 and 2 (each within the scatter of the next).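

In this assay, within the data shown here, putting 4-fluorophenyl in place of 2-(trifluoromethyl)phenyl on the oxygen whose other neighbour is the sulfonyl sulfur gives a 1.1-fold lower number from compound 1 to compound 4 (0.02 log units; within the scatter), the first direct reading of a single change at this position. For this one pair, going from a group of 10 heavy atoms with 3 fluorines to one of 7 heavy atoms with 1 fluorine leaves the read-out unchanged within the scatter, so this swap gives no sign that the trifluoromethyl group is needed for the activity seen in these cells. Nothing available on these compounds offers an explanation for this result.

The swap changes the group and the location of its fluorine together, so the two changes cannot be read apart, and compounds 2 and 3 differ from compound 1 in more than one place, which leaves any steps to them unreadable. On these data alone, it also stays open whether a much smaller group such as methyl, or a ring carrying an amine or a nitrile, on this same oxygen would shift the number beyond the scatter.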